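Fluoro to ethylcarbamoyl on compound 2

The compounds below may be only part of what the source reports. "The series", "measured", "known", "first", "only" and "open" are said of these compounds alone.

Measured so far in a functional assay on NCI-H1975 cells (Homo sapiens) for antiproliferative activity, read by CCK-8 assay, with a stated time of 72 h (a higher number here means a weaker inhibitor of growth, a lower number a stronger inhibitor of growth), for growth inhibition:
- compound 1 `CCCCNS(=O)(=O)c1ccc(Nc2ncc3c(n2)N(C2CCCC2)[C@H](CC)C(=O)N3C)cc1` gives 1610 nM
- compound 2 `CCC1C(=O)N(C)c2cnc(-n3ccc4cc(F)ccc43)nc2N1c1ccn(C)n1` gives 28600 nM

Compound 2 stands highest of the two numbers, and the gap down to compound 1 lies beyond the scatter. The two compounds differ in more than one place, so that gap gives no size for a single change.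

Compound 3 `CCNC(=O)c1ccc2c(ccn2-c2ncc3c(n2)N(c2ccn(C)n2)C(CC)C(=O)N3C)c1` keeps compound 2 except at one place, with ethylcarbamoyl in place of fluoro on an aromatic carbon in the six-membered aromatic ring of carbon only. Among the compounds with values here, no measured pair shows this change. Within the data shown here, the only guide is that compound 2 at 28600 nM is already high on the scale, so a moderate move toward a lower number is expected in this assay with wide uncertainty. The expected 3.2-fold lower number from compound 2 to compound 3 (0.50 log units; beyond the scatter) is a modest one and may end up not far beyond the scatter. The estimate for compound 3 is 9000 nM (range 2000 nM to 30000 nM).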

Compound 3, concentration for 50% growth inhibition: "not active" (no number reported)
No number was reported for compound 3, so the estimate cannot be set against anything.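

Within the data shown here, compound 3 is recorded as not active in this assay without a number, so no step from compound 2 to compound 3 can be read. No evidence on hand bears on this result. The compounds shown leave open how far ethylcarbamoyl in place of fluoro shifts growth inhibition in this assay and whether any other group at that place gives a lower number.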